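This account rests on a few compounds, and the source may have more. Where it says the series, first, only, none or still open, it means among the compounds named here.

Compound 1 `O=C1C(Nc2ccccc2)=CC(=O)c2c1nc1n2[C@H]2OC[C@@H](O)[C@H]2OC1`: 1830 nM
Compound 2 `O=C1C=C(Nc2ccccc2F)C(=O)c2c1nc1n2[C@H]2OC[C@@H](O)[C@H]2OC1`: 2080 nM
Compound 3 `O=C1C(NC2CC2)=CC(=O)c2c1nc1n2[C@H]2OC[C@@H](O)[C@H]2OC1`: a limit, given below

In a functional assay on MGC-803 cells (Homo sapiens) for inhibition, read by sulforhodamine B assay (on this read-out higher numbers stand for weaker inhibition and lower numbers for stronger inhibition), compound 1 gives 1830 nM and compound 2 gives 2080 nM, two numbers within the scatter of each other. For compound 3 this assay reports > 4000 nM, which is a limit rather than a number. Compound 4 `O=C1C=C(N2CCCC2)C(=O)c2c1nc1n2[C@H]2OC[C@@H](O)[C@H]2OC1` carries pyrrolidin-1-yl in place of (2-fluorophenyl)amino on a double-bonded ring carbon. Among the compounds with values here, the one measured step that speaks to it is an at least 2.1-fold higher number from compound 1 to compound 3 (0.33 log units; beyond the scatter), where an alkyl group replaced the phenyl on the amine and the number ran to the limit of > 4000 nM in this assay, at which 1 of the 3 values shown sits. Replacing the whole (2-fluorophenyl)amino group with pyrrolidin-1-yl removes the aromatic ring as well, so a weakening of similar or greater size is expected: a 2.2-fold higher number from compound 2 to compound 4 (0.34 log units; beyond the scatter). Compound 4 is therefore estimated at 4500 nM, between 2000 nM and 10000 nM, quite possibly reported only as a limit.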

Compound 4, half-maximal inhibitory concentration: > 16000 nM
Compound 4: a limit, no number (the forecaster's own chance of this, stated with the estimate: 55%); middle value at least 3.5-fold (0.55 log units) away from the limit.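

In this assay, putting pyrrolidin-1-yl in place of (2-fluorophenyl)amino on this double-bonded ring carbon gives an at least 7.6-fold higher number from compound 2 to compound 4 (0.88 log units; beyond the scatter). This is the first step shown at this carbon of compound 2, and it shows that the aromatic amine cannot be swapped for this saturated ring without a clear loss of inhibition. Compound 4 gives a limit, not a number: the limit of > 16000 nM in this assay, at which 1 of the 4 values shown sits.

The change removes the aromatic ring and the hydrogen-bond donor together, and the compounds shown do not separate the two. Cyclopentylamino, or an N-methylanilino group, would pull them apart.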